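The compounds below may be only part of what the source reports. "The series", "measured", "known", "first", "only" and "open" are said of these compounds alone.

Values measured in a functional assay on MCF7 cells (Homo sapiens) for antiproliferative activity, read by colorimetric assay and MTT assay, with a stated time of 48 h (on this read-out higher numbers stand for weaker inhibition and lower numbers for stronger inhibition), so far:
- Compound 1 `O=C(NS(=O)(=O)c1ccc(F)cc1)c1ccccn1` gives 11000 nM
- Compound 2 `O=C(NS(=O)(=O)c1ccc(Br)cc1)c1ccccn1` gives 6800 nM

These two numbers do not separate compound 2 from compound 1. Going by the values given here, the one measured step is a 1.6-fold lower number from compound 1 to compound 2 (0.21 log units; within the scatter) and it places compound 2 level with compound 1 within the scatter.

Compound 3 `Cc1ccc(S(=O)(=O)NC(=O)c2ccccn2)cc1` has not yet been measured. Its difference from compound 2 is methyl in place of bromo on an aromatic carbon and amounts to methyl in place of bromo on an aromatic carbon, para to a large group.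

Among the compounds with values here, because a 1.6-fold lower number from compound 1 to compound 2 (0.21 log units; within the scatter) is the only measured change at that place, no step beyond the scatter is expected in this assay for compound 3. Within the data shown here, the data hold no methyl example to refine this. The expected step is a 1.3-fold higher number from compound 2 to compound 3 (0.12 log units; within the scatter) and remains an estimate. The estimated value for compound 3 is 9000 nM with an expected range from 4500 nM to 18000 nM.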

Compound 3, half-maximal inhibitory concentration: 11800 nM
Estimate against measurement, compound 3: 1.3-fold (0.12 log units) below, and the stated range covers the measured number.
By their numbers in this assay, from the lowest: compounds 2, 1 and 3 (each within the scatter of the next).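

In this assay, methyl in place of bromo gives a 1.7-fold higher number from compound 2 to compound 3 (0.24 log units; within the scatter), and methyl in place of fluoro gives a 1.1-fold higher number from compound 1 to compound 3 (0.03 log units; within the scatter). The earlier compounds shown here compared only two halogens at this place, para to a large group, whereas compound 3 adds a carbon substituent and still does not separate from compound 1 or compound 2, so this change produces no step beyond the scatter in this small set. Nothing available here bears on why these numbers stay level.

The compounds shown leave open whether an amine, a carboxylic acid or a longer chain at this place would move the number beyond the scatter. They also leave open whether a change elsewhere on the shared core would have more effect than these substitutions.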